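A few compounds are considered here, and "the series" means these few. Any claim that something is new, unique, unknown or untested is made for them only; others in the source may bear on it.

Compound 1 `COc1ccc(C(=O)C(CC(=O)c2ccc(Cl)cc2)c2cn(-c3ccc(S(N)(=O)=O)cc3)nc2-c2ccc(C)cc2)cc1` gives 61.1% in a functional assay on the whole organism (strain Wistar albino) for inhibition, with Rattus norvegicus as the target, read by paw edema, with stated times of 1 h and 3 h, at a dose of 0.32 mmol/kg by the intraperitoneal route; on this read-out lower numbers stand for less inhibition and higher numbers for more inhibition at the one dose given (going by the name of the read-out).
Compound 2 `COc1ccc(-c2nn(-c3ccc(S(N)(=O)=O)cc3)cc2C(CC(=O)c2ccc(Cl)cc2)C(=O)c2ccc(F)cc2)cc1` gives 68.1% in this assay.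

In this assay compound 2 and compound 1 lie within the usual scatter of each other, so the two readings cannot be told apart. Compound 3 `COc1ccc(C(=O)C(CC(=O)c2ccc(Cl)cc2)c2cn(-c3ccc(S(N)(=O)=O)cc3)nc2-c2ccc(OC)cc2)cc1` has not been measured; it differs from compound 2 by methoxy in place of fluoro on an aromatic carbon. Among the measured compounds shown here, no measured pair shows this change, so its effect is unknown. The expected step of a number 5.1 percentage points lower from compound 2 to compound 3 (within the scatter) is small, not beyond the scatter, in either direction. Compound 3 is therefore estimated at 63%, with a range from 50% to 76%.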

Compound 3, a percentage reported as inhibition, in the whole organism at one dose (the size of the read-out at that dose, not a potency): 22.5%
Estimate against measurement, compound 3: 40.5 percentage points above, outside the stated range (below it).
By their numbers in this assay, from the lowest: compound 3; then compounds 1 and 2 (each within the scatter of the next).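

In this assay, the group on this benzoyl ring clearly matters: methoxy in place of fluoro gives a number 45.6 percentage points lower from compound 2 to compound 3 (beyond the scatter). Methoxy in place of methyl on a different aromatic ring gives a number 38.6 percentage points lower from compound 1 to compound 3 (beyond the scatter), so among these compounds the low reading appears only where methoxy stands at both places, as in compound 3. Nothing available explains this drop. On these data alone, whether the loss needs both methoxy groups or depends on the group at this position alone remains open. So does how a hydroxyl group or an amine would read here.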